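The source may report more compounds than this note shows. Statements on the series, on what has been measured and on what is new or still open speak of the compounds shown alone.

Of the compounds shown here, three with a shared core have been measured in a functional assay on HL-60 cells (Homo sapiens) for cytotoxicity, read by MTT assay, with a stated time of 72 h; on this read-out lower numbers stand for stronger inhibition and higher numbers for weaker inhibition. Compound 1 `Cc1ccc(S(=O)(=O)c2nc3ccccc3nc2N2CCCC2)cc1`, which carries a pyrrolidin-1-yl group, gives 9720 nM. Compound 2 `Cc1ccc(S(=O)(=O)c2nc3ccccc3nc2N2CCc3ccccc3C2)cc1`, with 1,2,3,4-tetrahydroisoquinolin-2-yl in that place, gives 3610 nM. Compound 3 `Cc1ccc(S(=O)(=O)c2nc3ccccc3nc2N2CCCC(O)C2)cc1`, with 3-hydroxypiperidin-1-yl there, gives 6080 nM. This value cannot be told apart from either of the other two, as the steps show: a 1.6-fold lower number from compound 1 to compound 3 (0.20 log units; within the scatter) and a 1.7-fold higher number from compound 2 to compound 3 (0.23 log units; within the scatter).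

Compound 4 `O=S(=O)(c1ccc(F)cc1)c1nc2ccccc2nc1N1CCCC(O)C1` keeps the 3-hydroxypiperidin-1-yl group of compound 3 and differs from it by fluoro in place of methyl on an aromatic carbon, para to a large group, which turns 4-methylphenyl into 4-fluorophenyl. Among the measured compounds shown here, no measured step touches this position, because all three exchange only the group that compound 3 and compound 4 share. The data therefore give no direct measure of this change and no direction for it. For the measured compounds named here, the only step beyond the scatter, a 2.7-fold lower number from compound 1 to compound 2 (0.43 log units; beyond the scatter), is modest, so no shift beyond the scatter is expected in this assay from this smaller exchange. The estimated step is a 1.0-fold lower number from compound 3 to compound 4 (0.01 log units; within the scatter). Compound 4 is expected to give about 6000 nM, with an estimated range of 2500 nM to 14000 nM.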

Compound 4, half-maximal inhibitory concentration: 2620 nM
Estimate against measurement, compound 4: 2.3-fold (0.36 log units) above, within the range that was stated.
By their numbers in this assay, from the lowest: compounds 4, 2, 3 and 1 (each within the scatter of the next, the first and the last beyond it).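

Among the compounds shown here, the position on the aromatic ring, which no earlier step touched, turns out to matter: in this assay the change from 4-methylphenyl to 4-fluorophenyl gives a 2.3-fold lower number from compound 3 to compound 4 (0.37 log units; beyond the scatter) and so lies beyond the usual scatter. The shift is modest, but it shows that the read-out responds to more than the group on the other side of the shared core, since swapping a single methyl for a single fluoro, with no change in heavy-atom count, is enough to move it. Nothing available here measures any property of these two groups, so the data show that the number moves but offer no explanation for the shift.

From the compounds shown here alone, this is a single pair, so it remains open whether fluoro in place of methyl would lower the number by a similar amount in compounds carrying pyrrolidin-1-yl or 1,2,3,4-tetrahydroisoquinolin-2-yl instead of 3-hydroxypiperidin-1-yl. Going by these compounds, it also remains open whether the change is specific to fluoro, or whether chloro, methoxy, trifluoromethyl or a plain hydrogen at this position would move the number in the same direction.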